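Swapping Methylsulfonyl for Methylsulfanyl on the Aromatic Ring

This account rests on a few compounds, and the source may have more. Where it says the series, first, only, none or still open, it means among the compounds named here.

Compound 1 `COc1ccc(SC)c(NCC2=NCCN2)c1`: 107 nM
Compound 2 `CS(=O)(=O)c1ccc(Cl)cc1NCC1=NCCN1`: 2400 nM

Among the measured compounds shown here, in an assay for binding affinity to Alpha-1D adrenergic receptor (Homo sapiens), read by radioligand binding (on this read-out higher numbers stand for weaker inhibition and lower numbers for stronger inhibition), compound 2 gives 2400 nM, the highest of the two numbers measured so far. Compound 1, the nearest neighbour, gives 107 nM, a gap well beyond the scatter of this assay.

The step to compound 3 `CSc1ccc(Cl)cc1NCC1=NCCN1` changes one group: methylsulfanyl in place of methylsulfonyl on an aromatic carbon. For the measured compounds named here, no measured pair covers this exact change, so its size has to be guessed. Because compound 1, which carries a methylsulfanyl group, gives 107 nM, the change is expected to lower the number, most likely by a good margin, though with wide uncertainty. The expected step from compound 2 to compound 3 in this assay is a 9.6-fold lower number from compound 2 to compound 3 (0.98 log units; beyond the scatter). For compound 3 the estimate in this assay is 250 nM, with a plausible range from 60 nM to 1000 nM.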

Compound 3, inhibition constant: 4.68 nM
Beside the measured number, compound 3's estimate is 53-fold (1.73 log units) above it, and the stated range ends above it.
By their numbers in this assay, from the lowest: compound 3; then compound 1; then compound 2.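

In this assay, this aromatic carbon, ortho to a group of 7 heavy atoms and para to a chloro group, proves highly sensitive to what it carries: methylsulfanyl in place of methylsulfonyl gives a 510-fold lower number from compound 2 to compound 3 (2.71 log units; beyond the scatter), the largest step seen so far. With methylsulfanyl kept, the second change also counts, as chloro in place of methoxy gives a 23-fold lower number from compound 1 to compound 3 (1.36 log units; beyond the scatter), so the low number depends on more than the sulfur-bearing group alone. No measurement shown here accounts for either step.

Going by these compounds, it remains open how a methylsulfinyl or ethylsulfanyl group would read on the same carbon, which would show whether the number moves gradually or only with these particular groups. Whether a fluoro or bromo group could replace chloro is also unresolved.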